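This account rests on a few compounds, and the source may have more. Where it says the series, first, only, none or still open, it means among the compounds named here.

Measured so far in an ADME assay on L6 cells (Rattus norvegicus) for cytotoxicity, read by resazurin assay, with a stated time of 72 h; on this read-out lower numbers stand for stronger inhibition and higher numbers for weaker inhibition:
Compound 1 `CC(C)c1ccc(C(=O)NC(=O)c2ccccc2O)cc1`: 19 ug/mL
Compound 2 `O=C(NC(=O)c1ccccc1O)c1ccc(-c2ccccc2)cc1`: > 100 ug/mL

The entry for compound 2 is a limit of the assay and not a number. Compound 2 thus stands at the limit of > 100 ug/mL in this assay, at which 1 of the 2 values shown sits. Compound 3 `N#Cc1ccc(C(=O)NC(=O)c2ccccc2O)cc1` has yet to be measured. It differs from compound 2 by cyano in place of phenyl on an aromatic carbon, with cyano in place of phenyl on an aromatic carbon, para to a large group. Among the compounds with values here, one measured step bears on this change: the swap of isopropyl for phenyl gave an at least 5.2-fold higher number from compound 1 to compound 2 (0.72 log units; beyond the scatter). Going by these compounds, its full size is unknown, since it ends at a limit. Removing the phenyl is therefore expected to move the number down in this assay, perhaps by a similar amount, towards compound 1 at 19 ug/mL. The expected step is an at least 2.5-fold lower number from compound 2 to compound 3 (0.39 log units; beyond the scatter). For compound 3 the estimate is 40 ug/mL. The expected range for compound 3 runs from 12 ug/mL to 100 ug/mL.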

Compound 3, half-maximal inhibitory concentration: 55 ug/mL
Compound 3: the middle estimate sits 1.4-fold (0.14 log units) below what was measured, within the range that was stated.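

In this assay, replacing the phenyl with cyano, para to a large group, does not by itself bring the number back to that of the isopropyl compound, since the step from the isopropyl compound is a 2.9-fold higher number from compound 1 to compound 3 (0.46 log units; beyond the scatter). This position therefore separates isopropyl from cyano by a measured amount, whereas the earlier pair gave only an open-ended step. Against phenyl the change reads as an at least 1.8-fold lower number from compound 2 to compound 3 (0.25 log units; that floor lies within the scatter), so its true size remains unknown, and compound 2 still stands at a limit of the assay and not a number: the limit of > 100 ug/mL in this assay, at which 1 of the 3 values shown sits.

Going by these compounds, it remains open whether an amine, a carboxylic acid or a longer chain at this position would give a number nearer that of the isopropyl or the cyano compound. How far compound 2 truly lies from compound 3 also stays unresolved.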